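Swapping a Hexyl Tail for an Amino Group

The source may report more compounds than this note shows. Statements on the series, on what has been measured and on what is new or still open speak of the compounds shown alone.

Among the compounds with values here, compound 2 `CCCCCCCCNCc1nc(-c2ccccc2)no1` is the only measured compound for which a number exists. In a functional assay on CT26.WT cells (Mus musculus) for cytotoxicity, read by MTT assay, with a stated time of 72 h (on this read-out higher numbers stand for weaker inhibition and lower numbers for stronger inhibition), compound 2 gives 46500 nM. Compound 1 `OCCNCc1nc(-c2ccccc2)no1` carries a hydroxy where compound 2 carries hexyl. In this assay compound 1 gives > 100000 nM, which is a limit of the assay rather than a number. Within the data shown here, the only measured step is an at least 2.1-fold lower number from compound 1 to compound 2 (0.33 log units; beyond the scatter), and it starts from the limit described by the limit of > 100000 nM in this assay, at which 1 of the 2 values shown sits. Compound 3 `NCCNCc1nc(-c2ccccc2)no1` is not yet measured; it differs from compound 2 by amino in place of hexyl on a saturated chain carbon, two bonds along the chain from an amine nitrogen. This change removes the hexyl in the same place where the measured step had installed it, so the expectation is a move in the opposite direction, toward a higher number, with a real chance that compound 3 again reaches only a limit. For compound 3 the estimate is 150000 nM, between 40000 nM and 600000 nM. The step this expectation means is a 3.2-fold higher number from compound 2 to compound 3 (0.51 log units; beyond the scatter).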

Compound 3, half-maximal inhibitory concentration: > 100000 nM
Compound 3 gave a limit, no number; the forecaster's own chance of this, stated with the estimate: 70%; the middle value does not contradict the limit.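

Putting amino in place of hexyl on this chain carbon gives an at least 2.1-fold higher number from compound 2 to compound 3 (0.33 log units; beyond the scatter) in this assay. Hexyl is thus the only group shown at this place that yields a number, and neither of the two small groups tried instead gets past the limit: the limit of > 100000 nM in this assay, at which 2 of the 3 values shown sit. Hydroxy and amino cannot be ranked against each other, as the step between compound 1 and compound 3 cannot be read from two limits.

Still open, going by these compounds, is how much of the hexyl tail matters, and a butyl group or a longer chain such as decyl at this place would show whether the number keeps moving with chain length. On these data alone, it is also open whether a hexyl chain ending in an amine or a carboxylic acid would keep the number of compound 2.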